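Methoxy for Methylsulfanyl: Working Notes on Compounds 1 to 4

The compounds below may be only part of what the source reports. "The series", "measured", "known", "first", "only" and "open" are said of these compounds alone.

Three compounds of the series have numbers in a functional assay on HTB-54 cells (Homo sapiens) for cytotoxicity, read by MTT assay, with a stated time of 72 h; a higher number here means a weaker inhibitor of growth, a lower number a stronger inhibitor of growth. Compound 1 `CSc1ccc(CNc2nc(SC)nc3ncccc23)cc1` gives 3280 nM in this assay. Compound 2 `COc1ccc(CNc2nc([SeH])nc3ccccc23)cc1` gives 7110 nM in this assay, and compound 3 `CSc1ccc(CNc2nc([SeH])nc3ccccc23)cc1` gives 45500 nM in this assay. Compound 1 thus stands lowest of the three, with compound 2 nearest and compound 3 furthest; both of those gaps lie beyond the usual scatter.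

Compound 2 and compound 3 share a core and differ in one place: methoxy in place of methylsulfanyl on an aromatic carbon. The measured step is a 6.4-fold lower number from compound 3 to compound 2 (0.81 log units; beyond the scatter). Compound 1 and compound 3 differ in more than one place, and the difference between the two cores is not broken down here.

Compound 4 `COc1ccc(CNc2nc(SC)nc3ncccc23)cc1` has not yet been measured. It relates to compound 1 as compound 2 relates to compound 3: methoxy in place of methylsulfanyl on an aromatic carbon. The place is described in the same words for both pairs, so this is the same kind of change, carried onto the core of compound 1. The expectation rests on one earlier pair on another core only, so the carried step is weighted down. For compound 4 the expected step is a 3.6-fold lower number from compound 1 to compound 4 (0.56 log units; beyond the scatter), smaller than the earlier one because a 6.4-fold lower number from compound 3 to compound 2 (0.81 log units; beyond the scatter) is a single observation on a different core. Compound 4 is therefore estimated at 900 nM in this assay, with an expected range from 300 nM to 3000 nM.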

Compound 4, concentration for 50% growth inhibition: > 100000 nM
Compound 4: a limit, no number (the forecaster's own chance of this, stated with the estimate: 2%); middle value at least 110-fold (2.04 log units) away from the limit.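

In this assay compound 4 gives > 100000 nM as a limit of the assay and not a number. On the core of compound 1, methoxy in place of methylsulfanyl on an aromatic carbon gives an at least 30-fold higher number from compound 1 to compound 4 (1.48 log units; beyond the scatter) as a bound on the step, not as its full size, and the direction is opposite to that of the same change on the other core. The two pairs show that, across these four compounds, the effect of this change in this assay does not carry from one core to the other, but they do not show which of the differences between the cores is responsible or how the change would behave on a third core, and the contrast rests on only two pairs: the same change on two cores in this assay, a 6.4-fold lower number (0.81 log units; beyond the scatter) from compound 3 to compound 2 and an at least 30-fold higher number (1.48 log units; beyond the scatter) from compound 1 to compound 4, at least 190-fold (2.29 log units) apart, beyond the scatter of two such steps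

The compounds shown leave open how far the step on the core of compound 1 really extends, and whether the loss belongs to methoxy alone or would also appear with an ethoxy group or a chlorine atom on that aromatic carbon. They also leave open whether an amine or a longer chain at the same place would follow compound 1 or compound 4 on this core.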